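This account rests on a few compounds, and the source may have more. Where it says the series, first, only, none or still open, it means among the compounds named here.

Working notes on the series. In a physicochemical assay for solubility, in simulated intestinal fluid, measured as kinetic solubility, at pH 6.5 (a higher number here means a more soluble compound, a lower number a less soluble compound), compound 1 `CCS(=O)(=O)c1ccc(COC[C@@H]2C[C@@H]2C2CCN(c3nc(C(C)C)no3)CC2)c(F)c1` gives 127000 nM, compound 2 `CC(C)c1noc(N2CCC([C@H]3C[C@H]3COCc3ccc(S(C)(=O)=O)cc3F)CC2)n1` gives 144000 nM and compound 3 `CCOc1cnc(N2CCC([C@H]3C[C@H]3COCc3ccc(S(C)(=O)=O)c(F)c3)CC2)nc1` gives 101000 nM, so compound 3 stands within the scatter of both others. The next structure, compound 4 `CCc1cnc(N2CCC([C@H]3C[C@H]3COCc3ccc(S(C)(=O)=O)c(F)c3)CC2)nc1`, differs from it as follows: ethyl in place of ethoxy on an aromatic carbon. This puts ethyl in place of ethoxy on an aromatic carbon. Going by the values given here, the only measured step, a 1.1-fold higher number from compound 1 to compound 2 (0.05 log units; within the scatter), lies within the scatter, but it is a change at the sulfonyl end, so it bears only indirectly. Among the compounds with values here, no measured step covers the ethoxy group. No step beyond the scatter is therefore expected in this assay, and the estimated step runs a 1.1-fold lower number from compound 3 to compound 4 (0.03 log units; within the scatter). For compound 4 the estimated value is 95000 nM, with an expected range of 45000 nM to 190000 nM.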

Compound 4, solubility: 140000 nM
Beside the measured number, compound 4's estimate is 1.5-fold (0.17 log units) below it; the range from low to high includes it.
By their numbers in this assay, from the lowest: compounds 3, 1, 4 and 2 (each within the scatter of the next).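

In this assay, going by these compounds alone, ethyl in place of ethoxy on this aromatic carbon gives a 1.4-fold higher number from compound 3 to compound 4 (0.14 log units; within the scatter), the first reading at this position. For this pair, the change from 5-ethoxypyrimidin-2-yl to 5-ethylpyrimidin-2-yl therefore stays within the scatter, so the ethoxy oxygen is not required to hold the solubility reading in this range. No measurement on hand accounts for the size of this step. The compounds shown leave open whether a longer chain, an amine or a carboxylic acid on this aromatic carbon would also stay within the scatter of compound 3.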